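Adding a Hydroxylated Chain at the Methyl of Compound 1

The source may report more compounds than this note shows. Statements on the series, on what has been measured and on what is new or still open speak of the compounds shown alone.

Compound 1, `Cc1c(Nc2nc(N)c3c(C#N)c(N4CCC[C@H]4C)n(C)c3n2)cnn1C`, has the lower of the two numbers obtained so far in an assay on isolated protein for inhibition of Leucine-rich repeat serine/threonine-protein kinase 2 variant G2019S (Homo sapiens), read by TR-FRET and LanthaScreen, with stated times of 50 min and 30 min, in the presence of a further agent that is not named here (a higher number here means a weaker inhibitor, a lower number a stronger inhibitor), where compound 1 gives 43 nM. Its companion, compound 2, `C[C@@H]1CCCN1c1c(C#N)c2c(N)nc(N)nc2n1C`, lacks the 1,5-dimethyl-1H-pyrazol-4-yl group on the nitrogen on the aromatic ring, and compound 2 gives 217 nM. The step of a 5.0-fold higher number from compound 1 to compound 2 (0.70 log units; beyond the scatter) shows the weight that this substituent carries in the measured pair. Compound 3, `Cc1c(Nc2nc(N)c3c(C#N)c(N4CCC[C@H]4C)n(C)c3n2)cnn1CC(C)(C)O`, keeps that substituent and extends it: 1-hydroxy-1-methylethyl in place of hydrogen on a saturated chain carbon bound to an aromatic nitrogen. For the measured compounds named here, no measured step addresses this change directly. Going by the values given here, the only step in hand, a 5.0-fold higher number from compound 1 to compound 2 (0.70 log units; beyond the scatter), concerns removal of the whole substituent rather than an addition at its methyl end, so it offers only a loose frame. With the core and the substituent that compound 1 relies on both kept intact, the addition is not expected to move the number much. Compound 3 is therefore expected to show a step of a 1.2-fold higher number from compound 1 to compound 3 (0.07 log units; within the scatter) that need not exceed the scatter in either direction. On that basis compound 3 is estimated at 50 nM, with a range from 18 nM to 140 nM.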

Compound 3, half-maximal inhibitory concentration: 35 nM
Compound 3: the middle estimate sits 1.4-fold (0.15 log units) above what was measured; measured number inside the range.
By their numbers in this assay, from the lowest: compounds 3 and 1 (each within the scatter of the next); then compound 2.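

In this assay, the step of a 1.2-fold lower number from compound 1 to compound 3 (0.09 log units; within the scatter) shows that the methyl on the aromatic nitrogen of the 1,5-dimethyl-1H-pyrazol-4-yl group can be replaced by 2-hydroxy-2-methylpropyl without a reading beyond the scatter, so compound 1 and compound 3 cannot be told apart here. The earlier step, a 5.0-fold higher number from compound 1 to compound 2 (0.70 log units; beyond the scatter), showed only that losing the whole substituent counts, whereas this one shows that the substituent's weight in the assay survives an addition of 1-hydroxy-1-methylethyl on the saturated chain carbon bound to an aromatic nitrogen. Nothing at hand explains why this addition leaves the number within the scatter.

The compounds shown leave open whether the hydroxyl itself plays any part, a question that 2-methylpropyl, the same chain without its hydroxyl, would address. They also leave open whether an amine, a carboxylic acid or a longer chain at this place would likewise stay within the scatter of compound 1, and so how much room this position really offers.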